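The source may report more compounds than this note shows. Statements on the series, on what has been measured and on what is new or still open speak of the compounds shown alone.

Compound 1 `Cc1ccc(OCC(=O)N(Cc2cccs2)c2ccccn2)cc1` gives 200 nM in an assay on HEK293 cells for agonist activity at transient receptor potential cation channel subfamily M member 8 (Homo sapiens), read by fluorescence and calcium flux, with a stated time of 15 min; a lower number here means that less compound is needed, a higher number that more compound is needed for the effect. Compound 2 `COCCN(Cc1cccs1)C(=O)COc1ccc(C)cc1` differs from it by 2-methoxyethyl in place of pyridin-2-yl on the amide-type nitrogen and gives 400 nM in this assay; the step is a 2.0-fold higher number from compound 1 to compound 2 (0.30 log units; within the scatter). For the measured compounds named here, compound 2 thus stands at the highest of the two numbers so far, with compound 1 nearest, and the two lie within the scatter of each other, so no order between them can be claimed.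

Compound 3 `Cc1ccc(OCC(=O)N(Cc2cccs2)c2cn[nH]c2)cc1` is not yet measured. Relative to compound 2 the change is 1H-pyrazol-4-yl in place of 2-methoxyethyl on an amide-type nitrogen; the 2-methoxyethyl chain gives way to a five-membered aromatic ring carrying one hydrogen-bond donor and one acceptor. Going by the values given here, the only measured step that bears on this is a 2.0-fold higher number from compound 1 to compound 2 (0.30 log units; within the scatter), which went the other way, from an aromatic ring on that nitrogen to the 2-methoxyethyl chain, and stayed within the scatter. Among the compounds with values here, the ring entering compound 3 is not pyridin-2-yl and brings a hydrogen-bond donor, for which no measured step exists. On that basis the step is expected to be small, a partial return toward the number of compound 1 at most, a 1.6-fold lower number from compound 2 to compound 3 (0.20 log units; within the scatter). Compound 3 is therefore estimated at 250 nM, with a range of 80 nM to 800 nM.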

Compound 3, half-maximal effective concentration: 1.4 nM
Compound 3: middle estimate off by 180-fold (2.25 log units), on the high side, outside the stated range (below it).
By their numbers in this assay, from the lowest: compound 3; then compounds 1 and 2 (each within the scatter of the next).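

Working from this assay, the substituent on the amide-type nitrogen, whose other neighbours are the carbonyl carbon and a saturated chain carbon, proves far more decisive than compound 1 and compound 2 suggested: 1H-pyrazol-4-yl in place of 2-methoxyethyl gives a 290-fold lower number from compound 2 to compound 3 (2.46 log units; beyond the scatter) and 1H-pyrazol-4-yl in place of pyridin-2-yl gives a 140-fold lower number from compound 1 to compound 3 (2.15 log units; beyond the scatter) on the same core. An aromatic ring at this position is thus not sufficient for the low number, since compound 1, with pyridin-2-yl, stays within the scatter of compound 2 and only the 1H-pyrazol-4-yl group reaches this level. Nothing measured in the compounds shown accounts for the size of these steps.

Open, going by these compounds, is whether the ring hydrogen on nitrogen matters, which a 1-methyl-1H-pyrazol-4-yl group on the same nitrogen would address, and whether the point of attachment matters, as a 1H-pyrazol-3-yl group would show. Also open, on these data alone, is whether other five-membered rings, such as imidazol-4-yl or 1,2,3-triazol-4-yl, give a comparable number.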